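Coumarin-bearing pyrazolines: from propanoyl to a pyrrolidinylacetyl chain

A few compounds are considered here, and "the series" means these few. Any claim that something is new, unique, unknown or untested is made for them only; others in the source may bear on it.

Measured compounds:
Compound 1, `CC1=NN(S(=O)(=O)c2ccc([N+](=O)[O-])cc2)C(c2cc(Cl)ccc2O)C1`: "not active" (no number reported)
Compound 2, `CC(=O)Oc1ccccc1C1CC(C)=NN1C(=O)CN(C(C)C)C(C)C`: 20100 nM
Compound 3, `CCC(=O)N1N=C(c2cc3ccccc3oc2=O)CC1c1ccccc1`: 5300 nM

In a functional assay on MGC-803 cells (Homo sapiens) for cytotoxicity, read by MTT assay, with a stated time of 48 h (a higher number here means a weaker inhibitor, a lower number a stronger inhibitor), compound 1 was reported only as "not active" (no number reported), with no number given. Compound 2, in this assay, gives 20100 nM. Compound 3, in this assay, gives 5300 nM, the lower of the two numbers on record, and the difference between compound 3 and compound 2 lies beyond the usual scatter.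

Compound 4, `O=C(CN1CCCC1)N1N=C(c2cc3ccccc3oc2=O)CC1c1ccccc1`, has not yet been measured. It differs from compound 3 by pyrrolidin-1-yl in place of methyl on a saturated chain carbon bound to a carbonyl carbon. Nothing measured here tracks a change of this kind on the shared core of compound 3, so the step is expected to be modest, with no clear direction beyond the scatter, and perhaps leaning toward a somewhat lower number. Compound 4 is therefore expected to come in near compound 3, with an estimated 4000 nM, ranging from 1500 nM to 12000 nM, which corresponds to an expected 1.3-fold lower number from compound 3 to compound 4 (0.12 log units; within the scatter).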

Compound 4, half-maximal inhibitory concentration: "not active" (no number reported)
Compound 4 has no reported number here; no gap can be computed for the estimate.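

In this assay compound 4 gives "not active" (no number reported) and so, with no number, yields no readable step from compound 3. No evidence on record bears on this result. The compounds shown leave open how far pyrrolidin-1-yl in place of methyl shifts activity on the shared core.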